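The source may report more compounds than this note shows. Statements on the series, on what has been measured and on what is new or still open speak of the compounds shown alone.

In a functional assay on MDA-MB-231 cells (Homo sapiens) for cytotoxicity, read by MTT assay, with a stated time of 48 h (on this read-out lower numbers stand for an effect already at smaller amounts and higher numbers for an effect only at larger amounts of compound), compound 1 `CO[C@H]1O[C@H](COc2cccc3c2CCCC3)[C@@H](O)[C@H](O)[C@H]1Oc1ccc(OC2CCCCC2)cc1` gives "not determined" (no result reported). Compound 2 `CO[C@H]1O[C@H](COc2ccc(OC3CCCCC3)cc2)[C@@H](O)[C@H](O)[C@H]1Oc1ccc(OC2CCCCC2)cc1` gives 20000 nM in this assay, and compound 3 `CO[C@H]1O[C@H](COc2ccccc2C(C)C)[C@@H](O)[C@H](O)[C@H]1Oc1ccc(OC2CCCCC2)cc1` gives 36000 nM; the two numbers lie within the usual scatter of each other, so neither stands apart. Compound 4 `CO[C@H]1O[C@H](COc2ccc(C3CCCCC3)cc2)[C@@H](O)[C@H](O)[C@H]1Oc1ccc(OC2CCCCC2)cc1` differs from compound 3 in one place: 4-cyclohexylphenyl in place of 2-isopropylphenyl on an oxygen on a saturated carbon. Within the data shown here, with no measured step connecting two compounds to lean on, the shape of the group entering resembles the group that compound 2 carries at the same oxygen, and compound 2 sits close to compound 3 in this assay. A step of a 1.6-fold lower number from compound 3 to compound 4 (0.21 log units; within the scatter) is therefore expected, none beyond the scatter. For compound 4 the estimate is 22000 nM, within a range of 8000 nM to 60000 nM.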

Compound 4, half-maximal effective concentration: 14000 nM
The estimate for compound 4 lay 1.6-fold (0.20 log units) above the measured number; the range from low to high includes it.
By their numbers in this assay, from the lowest: compounds 4, 2 and 3 (each within the scatter of the next, the first and the last beyond it).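

Among these compounds, at this oxygen on a saturated carbon, 4-cyclohexylphenyl in place of 2-isopropylphenyl gives a 2.6-fold lower number from compound 3 to compound 4 (0.41 log units; beyond the scatter) in this assay, the first step here to pass the scatter, though only a modest one. Cyclohexyl in place of cyclohexyloxy on an aromatic carbon gives a 1.4-fold lower number from compound 2 to compound 4 (0.15 log units; within the scatter), so that exchange does not separate the two compounds. Nothing available explains either step. Going by these compounds, it remains open how an amine or a carboxylic acid on the aromatic ring at this oxygen would read, or a longer chain in place of the cyclohexyl ring.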